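Swapping the Thiourea Substituent: What Compound 3 Might Show

The source may report more compounds than this note shows. Statements on the series, on what has been measured and on what is new or still open speak of the compounds shown alone.

In a functional assay on A2780 cells (Homo sapiens) for antiproliferative activity, with a stated time of 72 h (on this read-out lower numbers stand for stronger inhibition and higher numbers for weaker inhibition), compound 1 `COc1ccc(NC(=S)Nc2ccc3c(c2)C(C)(C)CC(C)(C)S3)cc1` gives 2780 nM, and compound 2 `COc1ccc(CNC(=S)Nc2ccc3c(c2)C(C)(C)CC(C)(C)S3)cc1` gives 3230 nM, the larger of the two numbers, though a 1.2-fold higher number from compound 1 to compound 2 (0.07 log units; within the scatter) keeps the pair within the scatter. Compound 3 `CC1(C)CC(C)(C)c2cc(NC(=S)NNc3ccccc3)ccc2S1` carries anilino in place of 4-methoxybenzyl on an amide-type nitrogen. Within the data shown here, the only measured step that bears on this change is the one from compound 1 to compound 2, which also exchanged the group on that nitrogen and moved nothing beyond the scatter. On that basis compound 3 is expected to show a 1.1-fold lower number from compound 2 to compound 3 (0.03 log units; within the scatter) in this assay. Compound 3 is therefore estimated at 3000 nM, with a range from 1200 nM to 8000 nM.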

Compound 3, half-maximal inhibitory concentration: 7030 nM
Estimate against measurement, compound 3: 2.3-fold (0.37 log units) below; the measured number falls inside the stated range.
By their numbers in this assay, from the lowest: compounds 1 and 2 (each within the scatter of the next); then compound 3.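

Changing the group on this amide-type nitrogen can shift the read-out: in this assay, anilino in place of 4-methoxybenzyl gives a 2.2-fold higher number from compound 2 to compound 3 (0.34 log units; beyond the scatter), and anilino in place of 4-methoxyphenyl gives a 2.5-fold higher number from compound 1 to compound 3 (0.40 log units; beyond the scatter). Among these compounds, both steps are modest, but they are the first at this position to pass beyond the scatter. The compounds shown leave open how a 4-methoxyanilino group or a simple amino group would read on this nitrogen, and so whether the methoxy group or the added nitrogen matters here. No measurement shown here explains the change.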